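Swapping piperidinyl for phenyl on the amide side chain

The source may hold more compounds than are shown below. What is called first, only, known or untested is meant among the compounds shown, and "the series" means these compounds.

Measured compounds:
Compound 1, `Cc1cc(C)cc(S(=O)(=O)c2c(C(=O)NCc3ccccc3)[nH]c3ccc(Cl)c(F)c23)c1`: in an ADME assay on CCRF-CEM cells (Homo sapiens) for cytotoxicity, read by cell counting (a higher number here means that more compound is tolerated, a lower number that less compound is tolerated), compound 1 gives 15000 nM.
Compound 2, `Cc1cc(C)cc(S(=O)(=O)c2c(C(=O)NCN3CCCCC3)[nH]c3ccc(Cl)cc23)c1`: in this assay compound 2 gives 9900 nM.
Compound 3, `Cc1cc(C)cc(S(=O)(=O)c2c(C(=O)NCN3CCCCC3)[nH]c3ccc([N+](=O)[O-])cc23)c1`: in this assay compound 3 gives 12000 nM.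

All three numbers sit close together, and every gap between them is within the scatter, so compound 2 cannot be set apart from compound 1 or compound 3 on these data. Within the data shown here, the one single-point step that has been measured, a 1.2-fold higher number from compound 2 to compound 3 (0.08 log units; within the scatter), changes a group on the aromatic ring of the shared core and leaves the amide side chain untouched.

Compound 4, `Cc1cc(C)cc(S(=O)(=O)c2c(C(=O)NCc3ccccc3)[nH]c3ccc(Cl)cc23)c1`, differs from compound 2 by phenyl in place of piperidin-1-yl on a saturated chain carbon bound to an amide-type nitrogen. Among the measured compounds shown here, no measured pair isolates this change. Compound 1 carries the same benzyl amide as compound 4, but it also bears an extra fluoro on its core, so the values of compound 1 and compound 2 can only be said to lie within the scatter of each other.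

Given that every measured comparison stays within the scatter, the step of a 1.2-fold higher number from compound 2 to compound 4 (0.08 log units; within the scatter) is expected to stay within the scatter as well. Compound 4 is therefore estimated to give 12000 nM, with a likely range from 6000 nM to 25000 nM.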

Compound 4, half-maximal cytotoxic concentration: 244000 nM
Estimate against measurement, compound 4: 20-fold (1.31 log units) below; the whole stated range lies below it.
By their numbers in this assay, from the lowest: compounds 2, 3 and 1 (each within the scatter of the next); then compound 4.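

In this assay, among these compounds, phenyl in place of piperidin-1-yl on a saturated chain carbon bound to an amide-type nitrogen gives a 25-fold higher number from compound 2 to compound 4 (1.39 log units; beyond the scatter) and so shows that this position can shift the number strongly, which the earlier compounds, all within the scatter of each other, gave no sign of. The benzylcarbamoyl group alone does not guarantee a high number, since compound 1 carries it too, and hydrogen in place of fluoro on an aromatic carbon of the shared core gives a 16-fold higher number from compound 1 to compound 4 (1.21 log units; beyond the scatter) as a second large step. The high number of compound 4 therefore depends on its whole structure and not on the side chain alone, and nothing at hand explains either step.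

The compounds shown leave open whether the aromatic ring of the phenyl or the loss of the ring nitrogen of the piperidin-1-yl drives the first step, and a cyclohexyl group in the same place would separate the two. They also leave open whether the benzylcarbamoyl group would give a similar step on the nitro core of compound 3.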